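This account rests on a few compounds, and the source may have more. Where it says the series, first, only, none or still open, it means among the compounds named here.

Compound 1 `CCCn1c(=O)[nH]c2nc(-c3ccc(S(=O)(=O)N4CCN(c5ccc(F)cc5)CC4)cc3)[nH]c2c1=O` was examined in an assay on CHO cells for displacement of a labelled ligand from adenosine receptor A3 (Homo sapiens), read by scintillation counting, with a stated time of 45 min, in the presence of a further agent that is not named here; on this read-out higher numbers stand for weaker inhibition and lower numbers for stronger inhibition. In this assay compound 1 gives > 1000 nM, which is a limit of the assay and not a number. Compound 2 `CCCn1c(=O)[nH]c2nc(-c3ccc(S(=O)(=O)N4CCN(Cc5cccc(C)c5)CC4)cc3)[nH]c2c1=O` gives > 1000 nM in this assay, again only a limit. Compound 3 `CCCn1c(=O)[nH]c2nc(-c3ccc(S(=O)(=O)N4CCN(c5cccc(Br)c5)CC4)cc3)[nH]c2c1=O` gives > 1000 nM in this assay, also a limit. Compound 1 thus stands where every measured compound stands, at the limit of > 1000 nM in this assay, at which 3 of the 3 values shown sit. The three measured steps, a step that the two limits leave unreadable from compound 1 to compound 2, a step that the two limits leave unreadable from compound 1 to compound 3 and a step that the two limits leave unreadable from compound 2 to compound 3, therefore carry no readable size and no direction.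

Compound 4 `CCCn1c(=O)[nH]c2nc(-c3ccc(S(=O)(=O)N4CCN(c5ccc(I)cc5)CC4)cc3)[nH]c2c1=O` has not yet been measured. It differs from compound 1 by iodo in place of fluoro on an aromatic carbon. No measured step alters the group in this way, and each measured step ends at a limit, so the shown data give no size to expect in this assay for this change. Compound 4 is expected to give about 3000 nM in this assay, within 1000 nM to 10000 nM, most probably again reported as a limit. The step that the limit leaves unreadable from compound 1 to compound 4 is accordingly expected to remain unreadable rather than to show movement beyond the scatter.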

Compound 4, inhibition constant: > 1000 nM
Compound 4: only a limit was reported; the forecaster's own chance of this, stated with the estimate: 85%; the middle value does not contradict the limit.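

In this assay, going by these compounds alone, compound 4 gives > 1000 nM, a limit and not a number, so no step joining it to compound 1, compound 2 or compound 3 can be read: the limit of > 1000 nM in this assay, at which 4 of the 4 values shown sit. The compounds shown leave open whether any group on the amine nitrogen in the ring changes the inhibition constant, and by how much.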